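The source may hold more compounds than are shown below. What is called first, only, known or untested is meant among the compounds shown, and "the series" means these compounds.

Compound 3 `COc1ccc(-c2nc3cc(Cl)c(Cl)cc3[nH]2)cc1` stands alone among the three measured compounds in giving an actual number in an ADME assay on BHK cells (Mesocricetus auratus) for cytotoxicity, read by MTT assay, with a stated time of 96 h; a higher number here means that more compound is tolerated, a lower number that less compound is tolerated: compound 3 gives 18000 nM. The other two values are limits of the assay rather than numbers. Compound 1 `COc1ccc(-c2nc3cc(C(F)(F)F)ccc3[nH]2)c(N)c1` sits at a limit, giving >= 100000 nM in this assay. Compound 2 `COc1ccc(-c2nc3cc(Cl)c(Cl)cc3[nH]2)c(N)c1` likewise sits at a limit, giving > 100000 nM in this assay. Going by the values given here, the one measured step, an at least 5.5-fold lower number from compound 2 to compound 3 (0.74 log units; beyond the scatter), shows that removing the amino group moved the value from a limit to a number.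

Compound 4 `CC(=O)Nc1ccc(-c2nc3cc(Cl)c(Cl)cc3[nH]2)cc1` differs from compound 3 at another spot: acetamido in place of methoxy on an aromatic carbon. Among the compounds with values here, no measured step touches the methoxy group, so the step from compound 2 to compound 3, which concerns an amino group elsewhere on the shared core, gives no direct guide to this change. With nothing in the measured pairs bearing on it, no step beyond the scatter is expected in this assay, though the uncertainty is wide. The expected change is a 1.4-fold higher number from compound 3 to compound 4 (0.14 log units; within the scatter). Compound 4 is therefore estimated at about 25000 nM, with a likely range from 8000 nM to 80000 nM.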

Compound 4, half-maximal cytotoxic concentration: > 100000 nM
Compound 4 gave a limit, no number; the forecaster's own chance of this, stated with the estimate: 20%; middle value at least 4.0-fold (0.60 log units) away from the limit.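

Acetamido in place of methoxy gives an at least 5.5-fold higher number from compound 3 to compound 4 (0.74 log units; beyond the scatter) in this assay. Going by these compounds alone, this is the first sign that the group on this aromatic carbon, para to a large group, affects how much compound the cells tolerate, since the only earlier step concerned the amino group elsewhere on the shared core. The true size of the new step stays unknown, because the value for compound 4 is a limit and not a number: the limit of > 100000 nM in this assay, at which 2 of the 4 values shown sit.

Compound 3 is now reached by two separate single changes at two different places, one from compound 2 and one from compound 4, and both of those compounds sit at a limit, but these two steps alone cannot establish any wider pattern. The compounds shown leave open which part of the acetamido group matters, since a plain amine, a hydroxyl or a longer chain such as propionamido on this same carbon could separate the role of the amide hydrogen, the carbonyl and the size of the group.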